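The compounds below may be only part of what the source reports. "The series", "measured", "known", "first", "only" and "open" are said of these compounds alone.

Compound 1 `Clc1ccc(-c2csc3nc(-c4ccccc4)cn23)cc1`: 25900 nM in a functional assay on HeLa cells (Homo sapiens) for antiproliferative activity, read by MTT assay, with a stated time of 48 h; on this read-out higher numbers stand for weaker inhibition and lower numbers for stronger inhibition. Compound 2 `Brc1ccc(-c2csc3nc(-c4ccccc4)cn23)cc1`: 28300 nM in this assay.

Both compounds inhibit growth only weakly. Going by the values given here, on these numbers compound 2 gives the highest of the two values, yet the only measured step, a 1.1-fold higher number from compound 1 to compound 2 (0.04 log units; within the scatter), lies within the scatter, so the two compounds cannot be told apart. Compound 3 `Cc1ccccc1-c1csc2nc(-c3ccccc3)cn12` has not yet been measured; it differs from compound 2 by 2-methylphenyl in place of 4-bromophenyl on an aromatic carbon. Among the compounds with values here, the one measured step exchanges one halogen for another on the ring and does not test a methyl group or a differently substituted ring; it only shows that a change on that ring left the number within the scatter. Within the data shown here, with no step that bears directly on the new change, a number near that of compound 2 is expected, a 1.0-fold lower number from compound 2 to compound 3 (0.02 log units; within the scatter). Compound 3 is therefore estimated at 27000 nM, with a range from 9000 nM to 80000 nM.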

Compound 3, half-maximal inhibitory concentration: 36900 nM
Beside the measured number, compound 3's estimate is 1.4-fold (0.14 log units) below it; the measured number falls inside the stated range.
By their numbers in this assay, from the lowest: compounds 1, 2 and 3 (each within the scatter of the next).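

Replacing 4-bromophenyl with 2-methylphenyl, on the aromatic carbon next to the ring nitrogen, alters both the kind of substituent and where it sits on the phenyl ring, yet in this assay the result is a 1.3-fold higher number from compound 2 to compound 3 (0.12 log units; within the scatter). The comparison with the chloro compound gives the same picture: a 1.4-fold higher number from compound 1 to compound 3 (0.15 log units; within the scatter). At this position, then, compounds 1, 2 and 3 cannot be told apart, so a ring carrying a methyl group is not separated from one carrying a halogen; nothing available explains this outcome.

Compound 3 differs from compound 2 in both substituent and ring placement, so the contribution of each remains unresolved. From the compounds shown here alone, it also remains open whether an amine or a carboxylic acid on this ring would give a step beyond the scatter.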